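Dropping One Fluoro: Expected Effect on Cell Cytotoxicity

The source may hold more compounds than are shown below. What is called first, only, known or untested is meant among the compounds shown, and "the series" means these compounds.

Two compounds have been measured in a functional assay on HT-29 cells (Homo sapiens) for cytotoxicity, read by MTT assay, with a stated time of 72 h; a higher number here means a weaker inhibitor, a lower number a stronger inhibitor:

Compound 1 `COc1ccc(-n2nnc(C(=O)Nc3ccc(Oc4ccnc5[nH]ccc45)c(F)c3)c2C)cc1` gives 590 nM.
Compound 2 `Cc1c(C(=O)Nc2ccc(Oc3ccnc4[nH]ccc34)c(F)c2)nnn1-c1ccc(F)c(F)c1` gives 610 nM.

Compound 2 stands at the higher of these two numbers, but the gap to compound 1 is tiny: the step of a 1.0-fold higher number from compound 1 to compound 2 (0.01 log units; within the scatter) lies within the scatter, so the two compounds cannot be told apart on potency. That step swaps the group on the aromatic nitrogen and says nothing about the central ring.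

Compound 3 `Cc1c(C(=O)Nc2ccc(Oc3ccnc4[nH]ccc34)cc2)nnn1-c1ccc(F)c(F)c1` differs from compound 2 in one place: hydrogen in place of fluoro on an aromatic carbon. Among the compounds with values here, no measured step touches this position; the only available step changes another part of the molecule and was itself within the scatter. With no evidence that this fluoro matters, the expectation is a step of a 1.1-fold higher number from compound 2 to compound 3 (0.03 log units; within the scatter) in this assay, which is to say no change beyond the scatter. Compound 3 is therefore estimated at 650 nM, within a range from 250 nM to 1700 nM, reflecting the uncertainty of an untested position.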

Compound 3, half-maximal inhibitory concentration: 1070 nM
The estimate for compound 3 lay 1.6-fold (0.22 log units) below the measured number, within the range that was stated.
By their numbers in this assay, from the lowest: compounds 1, 2 and 3 (each within the scatter of the next).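

In this assay, within the data shown here, hydrogen in place of fluoro on this aromatic carbon gives a 1.8-fold higher number from compound 2 to compound 3 (0.24 log units; within the scatter) and so provides the first measured step at this position, since the earlier pair of compounds differed only in the group on the aromatic nitrogen. This step is printed as within the scatter, so compound 2 and compound 3 cannot be told apart on potency, and the data do not show that this fluoro matters for the cytotoxicity read-out. The comparison covers the exchange of one fluorine atom for hydrogen at a place ortho to one large group and meta to another, and no available measurement bears on the result beyond the number itself.

From the compounds shown here alone, it remains open whether a different group on the same aromatic carbon, such as chloro, methoxy or an amine, would give a step beyond the scatter. Going by these compounds, this exchange has also been read only with 3,4-difluorophenyl on the aromatic nitrogen, so it is open whether the same exchange in compound 1, which carries 4-methoxyphenyl there, would also stay within the scatter.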